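Pivaloyloxymethyl carbamate: stability in rat liver S9

A few compounds are considered here, and "the series" means these few. Any claim that something is new, unique, unknown or untested is made for them only; others in the source may bear on it.

Among the measured compounds shown here, compound 2 `CC(C)C(=O)OCOC(=O)N1CCN(C(=O)c2nc(Nc3cc(C4CC4)[nH]n3)c3cc(Cl)ccc3n2)C[C@H]1C` stands lowest of the two numbers so far in an ADME assay on S9 fraction from liver (Rattus norvegicus), read by LC-MS, with a stated time of 60 min, at 37 degrees C (a higher number here means that more of the compound is left, a lower number that less of the compound is left), giving 14%. Compound 1 `CC(C)COC(=O)N1CCN(C(=O)c2nc(Nc3cc(C4CC4)[nH]n3)c3cc(Cl)ccc3n2)C[C@H]1C` gives 61.1% in this assay. For the measured compounds named here, the one measured step, a number 47.1 percentage points lower from compound 1 to compound 2 (beyond the scatter), exchanges the isobutyl carbamate for the acyloxymethyl carbamate, a different position from the change now at hand. Compound 3 `C[C@@H]1CN(C(=O)c2nc(Nc3cc(C4CC4)[nH]n3)c3cc(Cl)ccc3n2)CCN1C(=O)OCOC(=O)C(C)(C)C` differs from compound 2 by methyl in place of hydrogen on a saturated chain carbon bound to a carbonyl carbon and two saturated chain carbons, keeping the acyloxymethyl carbamate of compound 2 intact. Going by the values given here, no measured step addresses this change directly, so the expectation is anchored on compound 2, with wide uncertainty. Compound 3 is expected to fall above compound 2 in this assay, by a number 16 percentage points higher from compound 2 to compound 3 (beyond the scatter), though an outcome within the scatter of compound 2 cannot be excluded. The estimate for compound 3 is 30%, with a range from 10% to 60%.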

Compound 3, percent of the compound remaining: 47%
Estimate against measurement, compound 3: 17 percentage points below, and the stated range covers the measured number.
By their numbers in this assay, from the lowest: compound 2; then compound 3; then compound 1.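

In this assay the change of isopropylcarbonyl to (tert-butyl)carbonyl, with the rest of the acyloxymethyl carbamate kept, gives a number 33 percentage points higher from compound 2 to compound 3 (beyond the scatter) and so a single methyl on this carbon moves the number by a large step. Set against the isobutyl carbamate, the step is a number 14.1 percentage points lower from compound 1 to compound 3 (beyond the scatter) and is modest where the earlier one with isopropylcarbonyl was large, so the acyloxymethyl carbamate is not tied to a large loss in this series. Nothing at hand gives a reason for either step.

Open, as far as these compounds go, is whether a cyclohexyl group or a longer chain in place of tert-butyl would leave more of the compound, and whether an amine on that chain would change the picture. Also open, from the compounds shown here alone, is which part of each molecule is lost during the incubation.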